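A few compounds are considered here, and "the series" means these few. Any claim that something is new, unique, unknown or untested is made for them only; others in the source may bear on it.

Measured so far in an assay on isolated protein for inhibition of Amine oxidase [flavin-containing] B (Homo sapiens), read by fluorescence and Amplex Red, with stated times of 15 min and 20 min; on this read-out lower numbers stand for stronger inhibition and higher numbers for weaker inhibition:
compound 1 `C#CCN(CCCOc1ccc2ccc(=O)oc2c1)Cc1ccc(F)c(F)c1` gives 4860 nM
compound 2 `C#CCN(CCCOc1ccc2ccc(=O)oc2c1)Cc1ccccc1` gives 3740 nM

Going by the values given here, compound 2 carries the lower of the two numbers, but its only neighbour is compound 1, and that gap, a 1.3-fold lower number from compound 1 to compound 2 (0.11 log units; within the scatter), lies within the scatter, so the two compounds cannot be told apart on this read-out. Compound 3 `C#CCN(CCCOc1ccc2ccc(=O)oc2c1)Cc1ccc(C(C)C)cc1` has not yet been measured. It differs from compound 2 by isopropyl in place of hydrogen on an aromatic carbon, a change on an aromatic carbon of a six-membered aromatic ring of carbon only. Among the compounds with values here, the one measured step concerns the same ring, but it swaps fluorine atoms for hydrogen rather than adding an alkyl group, and it left the number where it was. Within the data shown here, no measured step shows what an isopropyl group on this ring does, so the expectation for compound 3 rests on compound 2 alone. The step expected from compound 2 to compound 3, a 1.2-fold lower number from compound 2 to compound 3 (0.07 log units; within the scatter), is therefore small, with no direction beyond the scatter. Compound 3 is expected to give about 3200 nM in this assay, within a range from 1000 nM to 10000 nM.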

Compound 3, half-maximal inhibitory concentration: 7580 nM
Beside the measured number, compound 3's estimate is 2.4-fold (0.37 log units) below it; the range from low to high includes it.
By their numbers in this assay, from the lowest: compounds 2, 1 and 3 (each within the scatter of the next, the first and the last beyond it).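

In this assay, going by these compounds alone, this is the first change on the ring to move the number beyond the scatter: a 2.0-fold higher number from compound 2 to compound 3 (0.31 log units; beyond the scatter) is a modest step towards weaker inhibition, so isopropyl on this aromatic carbon, para to a large group, brings no gain over hydrogen. The step is small and only just clears the scatter, and the other comparison stays inside it: a 1.6-fold higher number from compound 1 to compound 3 (0.19 log units; within the scatter) leaves compound 1 and compound 3 impossible to tell apart, so the 4-isopropylphenyl and 3,4-difluorophenyl groups cannot be separated on this read-out. Nothing available accounts for the change seen on adding isopropyl.

From the compounds shown here alone, it remains open whether methyl or tert-butyl on the same aromatic carbon would move the number in the same direction, which would show whether this step belongs to a trend or to isopropyl alone. Also open is how a group carrying oxygen or nitrogen, such as methoxy or an amine, would behave at this carbon, since the only groups shown on the ring so far are fluorine atoms and isopropyl.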